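A few compounds are considered here, and "the series" means these few. Any claim that something is new, unique, unknown or untested is made for them only; others in the source may bear on it.

Measured compounds:

Compound 1 `CCCn1c(SCc2ccc([N+](=O)[O-])cc2)nc2c1c(=O)[nH]c(=O)n2C` — 19.8%
Compound 2 `CCCn1c(SCC(=O)Nc2ccc(C)cc2)nc2c1c(=O)[nH]c(=O)n2C` — 42.2%
Compound 3 `Cn1cnc2c1c(=O)n(CC(=O)O)c(=O)n2C` — 0.8%

These three were tested in a functional assay on MGC-803 cells (Homo sapiens) for inhibition, read by MTT assay, with a stated time of 48 h, tested at 20 uM; on this read-out higher numbers stand for more inhibition at the one concentration tested (going by the name of the read-out) and lower numbers for less inhibition. Compound 3 stands lowest of the three; compound 1 lies above it by an amount beyond the usual scatter, and compound 2 lies higher still, again beyond the scatter. For the measured compounds named here, no pairwise step between the measured compounds has been worked out, so only these values themselves can be compared, and compound 3 shares no single-point change with either of the other two.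

Compound 4 `Cn1cnc2c1c(=O)n(CC(=O)N1CCC(F)(F)CC1)c(=O)n2C` is not yet measured. It differs from compound 3 in one place: 4,4-difluoropiperidin-1-yl in place of hydroxy on a carbonyl carbon. Nothing measured here shows what this particular change does on the core that compounds 3 and 4 share, so any expectation rests on compound 3 alone, whose value in this assay is 0.8%. A modest step upward is expected, but one that may well stay within the scatter; the step from compound 3 to compound 4 is estimated at a number 7.2 percentage points higher from compound 3 to compound 4 (within the scatter). For compound 4 the expected value in this assay is 8%, with a range from 0% to 30%.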

Compound 4, a percentage reported as inhibition, at one concentration (the size of the read-out at that concentration, not a potency): 11.3%
The estimate for compound 4 lay 3.3 percentage points below the measured number; the range from low to high includes it.
By their numbers in this assay, from the lowest: compound 3; then compounds 4 and 1 (each within the scatter of the next); then compound 2.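

In this assay, for the compounds shown here, putting 4,4-difluoropiperidin-1-yl in place of hydroxy on a carbonyl carbon gives a number 10.5 percentage points higher from compound 3 to compound 4 (beyond the scatter), a modest change, but the earlier compounds offered no step at all at this position. It shows that the number on the shared core does respond to what is attached to this carbonyl carbon, although this single step swaps a hydroxy for a six-membered non-aromatic ring and loses a hydrogen-bond donor all at once, so it cannot say which of these differences counts. Nothing in the data shown gives a reason for the rise.

Left open is whether the fluorine atoms take part, which plain piperidin-1-yl on the same carbonyl carbon would test, and whether a ring is needed at all, which an open-chain amine such as diethylamino would test. Also open, as far as these compounds go, is what a longer chain carrying this carbonyl carbon would do.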